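A few compounds are considered here, and "the series" means these few. Any claim that something is new, unique, unknown or untested is made for them only; others in the source may bear on it.

Three compounds of the series have numbers in a functional assay on the whole organism (plasma) with Mus musculus as the target, with a stated time of 15 days, at a dose of 30 mg/kg by the oral route; on this read-out lower numbers stand for a weaker effect and higher numbers for a stronger effect at the one dose given. Compound 3 `Cc1ccc(CN2C(=O)S/C(=C\c3ccc(O)cc3)C2=O)cc1` gives 37.3% there and stands alongside compound 2 `Cc1ccc(CN2C(=O)S/C(=C\c3ccc(N(C)C)cc3)C2=O)cc1`, which gives 40.8%, the step of a number 3.5 percentage points lower from compound 2 to compound 3 (within the scatter) being within the scatter; both lie well above compound 1 `Cc1ccc(CN2C(=O)S/C(=C\c3ccc(F)cc3)C2=O)cc1`, which gives 13.5%, with a number 23.8 percentage points higher from compound 1 to compound 3 (beyond the scatter) and a number 27.3 percentage points higher from compound 1 to compound 2 (beyond the scatter). Compound 4 `Cc1ccc(CN2C(=O)S/C(=C\c3ccc(Cl)cc3)C2=O)cc1` differs from compound 3 by chloro in place of hydroxy on an aromatic carbon. Going by the values given here, the steps that bear on this are the two out of compound 1, where a halogen was replaced and the number rose by a modest amount. Returning to a halogen in compound 4 is expected to give back much of that rise, so a drop beyond the scatter is expected. For compound 4 the expected value in this assay is 18%, ranging from 8% to 32%. That estimate corresponds to an expected step of a number 19.3 percentage points lower from compound 3 to compound 4 (beyond the scatter).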

Compound 4, a percentage reported as activity, at one dose (the size of the read-out at that dose, not a potency): 22.8%
Compound 4: middle estimate off by 4.8 percentage points, on the low side; the measured number falls inside the stated range.
By their numbers in this assay, from the lowest: compounds 1 and 4 (each within the scatter of the next); then compounds 3 and 2 (each within the scatter of the next).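

At this place, para to a large group, chloro gives a second halogen reading in this assay, with a number 14.5 percentage points lower from compound 3 to compound 4 (beyond the scatter) and a number 18 percentage points lower from compound 2 to compound 4 (beyond the scatter), so the low end of the series is not confined to fluoro. The two halogens are not separated, with a number 9.3 percentage points higher from compound 1 to compound 4 (within the scatter). Nothing measured here accounts for the gap between the halogens and the hydroxy and dimethylamino groups.

On these data alone, whether bromo falls with the halogens stays open, as does where a methyl, a methoxy or a carboxylic acid at this place would fall. As far as these compounds go, these readings give the size of the effect at the one dose used, and whether the effect would be stronger or weaker at any other dose stays open.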